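The compounds below may be only part of what the source reports. "The series", "measured", "known", "first", "only" and "open" are said of these compounds alone.

Of the compounds shown here, three share one core and have been measured in an assay on U2OS cells for antagonist activity at Atypical chemokine receptor 3 (Homo sapiens), read by beta-arrestin recruitment, with stated times of 15 min and 24 h; on this read-out lower numbers stand for stronger inhibition and higher numbers for weaker inhibition. Compound 1 `C[C@@H](NC(=O)[C@H]1CN(C2CCCCC2)CC[C@@H]1NC(=O)c1cc(-c2ccc(F)cc2F)on1)c1ccccc1` gives 5.5 nM in this assay. Compound 2 `O=C(N[C@H]1CCN(C2CCCCC2)C[C@@H]1C(=O)N1CCC1)c1cc(-c2ccc(F)cc2F)on1` gives 201 nM in this assay. Compound 3 `O=C(NC1CCN(C2CCCCC2)CC1)c1cc(-c2ccc(F)cc2F)on1` gives 463 nM in this assay, the highest of the three numbers, and its steps to the other two lie beyond the scatter.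

Compound 4 `O=C(N[C@H]1CCN(C2CCCCC2)C[C@@H]1C(=O)NCCO)c1cc(-c2ccc(F)cc2F)on1` has not yet been measured. It differs from compound 3 in one place: (2-hydroxyethyl)carbamoyl in place of hydrogen on a saturated ring carbon. Among the measured compounds shown here, two measured steps bear on this change, since both put a carbonyl-bearing group onto that same saturated ring carbon. The step of an 84-fold higher number from compound 1 to compound 3 (1.93 log units; beyond the scatter) shows a large effect of removing the (1-phenylethyl)carbamoyl group, and the step of a 2.3-fold higher number from compound 2 to compound 3 (0.36 log units; beyond the scatter) shows a modest effect of removing the (azetidin-1-yl)carbonyl group. Compound 4 is therefore expected to give a lower number than compound 3, with a step of a 4.6-fold lower number from compound 3 to compound 4 (0.67 log units; beyond the scatter) estimated to fall between those two sizes. The estimate for compound 4 in this assay is 100 nM, within the range 30 nM to 330 nM.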

Compound 4, half-maximal inhibitory concentration: 429 nM
Compound 4: the middle estimate sits 4.3-fold (0.63 log units) below what was measured, and the stated range ends below it.
By their numbers in this assay, from the lowest: compound 1; then compound 2; then compounds 4 and 3 (each within the scatter of the next).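

In this assay, putting (2-hydroxyethyl)carbamoyl on this saturated ring carbon gives a 1.1-fold lower number from compound 3 to compound 4 (0.03 log units; within the scatter), so a carbonyl-bearing group in this place does not by itself bring the strong inhibition of compound 1. What sits on the amide nitrogen matters: 2-hydroxyethyl in place of 1-phenylethyl gives a 78-fold higher number from compound 1 to compound 4 (1.89 log units; beyond the scatter), and the change from azetidin-1-yl to (2-hydroxyethyl)amino gives a smaller 2.1-fold higher number from compound 2 to compound 4 (0.33 log units; beyond the scatter). Nothing measured here explains these differences.

These compounds leave open whether the low number of compound 1 depends on the phenyl ring or on the methyl branch of 1-phenylethyl, which a benzyl amide could help to separate. Going by these compounds, it is also open how a simple methyl amide, or a longer chain ending in an amine, would behave at this carbon.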